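The source may hold more compounds than are shown below. What is called first, only, known or untested is meant among the compounds shown, and "the series" means these compounds.

Measured compounds:
- Compound 1 `CC(=O)OC[C@H]1O[C@@H](n2cc(CN3C(=O)/C(=C\c4ccccc4)c4ccccc43)nn2)[C@H](OC(C)=O)[C@@H](OC(C)=O)[C@@H]1OC(C)=O`: in an ADME assay on NIH3T3 cells (Homo sapiens) for cytotoxicity, read by sulforhodamine B assay, with a stated time of 48 h (a higher number here means a weaker inhibitor, a lower number a stronger inhibitor), compound 1 gives 22800 nM
- Compound 2 `CC(=O)OC[C@H]1O[C@@H](n2cc(CN3C(=O)/C(=C\C=C\c4ccccc4)c4ccccc43)nn2)[C@H](OC(C)=O)[C@@H](OC(C)=O)[C@@H]1OC(C)=O`: in this assay compound 2 gives 25900 nM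
- Compound 3 `CC(=O)OC[C@H]1O[C@@H](n2cc(CN3C(=O)/C(=C\c4ccc(N(C)C)cc4)c4ccccc43)nn2)[C@H](OC(C)=O)[C@@H](OC(C)=O)[C@@H]1OC(C)=O`: in this assay compound 3 gives 17000 nM

Of these three, compound 3 gives the lowest number, but its gaps to the others are small: from compound 1 the step is a 1.3-fold lower number from compound 1 to compound 3 (0.13 log units; within the scatter), and from compound 2 it is a 1.5-fold lower number from compound 2 to compound 3 (0.18 log units; within the scatter), both within the usual scatter, so the three compounds cannot be told apart on these numbers.

Compound 4 is `CC(=O)OC[C@H]1O[C@@H](n2cc(CN3C(=O)/C(=C\c4ccc5ccccc5c4)c4ccccc43)nn2)[C@H](OC(C)=O)[C@@H](OC(C)=O)[C@@H]1OC(C)=O`. Compared with compound 3, the change is naphthalen-2-yl in place of 4-(dimethylamino)phenyl on a double-bonded chain carbon bound to a double-bonded ring carbon. Every change so far at this same place, whether a 1.1-fold higher number from compound 1 to compound 2 (0.06 log units; within the scatter) or a 1.5-fold lower number from compound 2 to compound 3 (0.18 log units; within the scatter) or the addition of dimethylamino in a 1.3-fold lower number from compound 1 to compound 3 (0.13 log units; within the scatter), has left the number within the scatter. There is therefore no sign that swapping the group at this place moves the readout, and the expected step from compound 3 to compound 4 is a 1.2-fold higher number from compound 3 to compound 4 (0.09 log units; within the scatter), which is none beyond the scatter. For compound 4 the estimated value in this assay is 21000 nM, expected to lie between 11000 nM and 42000 nM.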

Compound 4, half-maximal inhibitory concentration: 80000 nM
For compound 4 the middle estimate is 3.8-fold (0.58 log units) below the measured one; the measured number lies above the stated range.
By their numbers in this assay, from the lowest: compounds 3, 1 and 2 (each within the scatter of the next); then compound 4.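

In this assay, among the compounds shown here, this position no longer looks indifferent to change: naphthalen-2-yl is the first group here to move the number beyond the scatter (a 4.7-fold higher number from compound 3 to compound 4 (0.67 log units; beyond the scatter); a 3.1-fold higher number from compound 2 to compound 4 (0.49 log units; beyond the scatter); a 3.5-fold higher number from compound 1 to compound 4 (0.55 log units; beyond the scatter)), which makes compound 4 the weakest inhibitor of the four. Going from compound 3 to compound 4 replaces one six-membered aromatic ring of carbon only with 2 such rings and also removes the nitrogen, and the two structures alone cannot separate these differences. No measurement shown here accounts for the rise.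

Going by these compounds, it remains open whether the higher number depends on the second ring or on losing the dimethylamino group. A quinolin-2-yl group, which keeps two rings but carries a ring nitrogen, or a phenyl ring bearing a carboxylic acid, could help separate those possibilities.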